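The source may report more compounds than this note shows. Statements on the series, on what has been measured and on what is new or still open speak of the compounds shown alone.

Measured so far:
Compound 1 `O=C(Nc1ccccc1)Nc1nnc(Sc2ncnc3scc(-c4ccncc4)c23)s1` gives 5700 nM in a functional assay on PC-3 cells (Homo sapiens) for antiproliferative activity, read by MTT assay, with a stated time of 48 h; on this read-out lower numbers stand for stronger inhibition and higher numbers for weaker inhibition.
Compound 2 `Cc1cccc(NC(=O)Nc2nnc(Sc3ncnc4scc(-c5ccncc5)c34)s2)c1` gives 5200 nM in this assay.

Compound 2 stands at the lower of these two numbers, but its gap to compound 1 is within the scatter. Among the measured compounds shown here, the only measured step, a 1.1-fold lower number from compound 1 to compound 2 (0.04 log units; within the scatter), was a change of one aromatic substituent that moved nothing beyond the scatter. Compound 3 `COc1ccc(NC(=O)Nc2nnc(Sc3ncnc4scc(-c5ccncc5)c34)s2)cc1` differs from compound 2 by 4-methoxyphenyl in place of 3-methylphenyl on an amide-type nitrogen. For the measured compounds named here, as the one comparable step was flat, no shift in this assay beyond the scatter is expected. Compound 3 is estimated at 5000 nM, with a range from 2000 nM to 12000 nM. For compound 3 this estimate means a 1.0-fold lower number from compound 2 to compound 3 (0.02 log units; within the scatter).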

Compound 3, half-maximal inhibitory concentration: 9900 nM
For compound 3 the middle estimate is 2.0-fold (0.30 log units) below the measured one; low and high end bracket the measured number.
By their numbers in this assay, from the lowest: compounds 2, 1 and 3 (each within the scatter of the next).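

With an oxygen-bearing group now on the aryl ring, a 1.9-fold higher number from compound 2 to compound 3 (0.28 log units; within the scatter) and a 1.7-fold higher number from compound 1 to compound 3 (0.24 log units; within the scatter) both stay within the scatter in this assay as well. At this amide-type nitrogen, therefore, phenyl, 3-methylphenyl and 4-methoxyphenyl cannot be told apart, and this holds for a methoxy substituent as it did for methyl. No available evidence explains these numbers.

As far as these compounds go, whether an amine or a carboxylic acid on this ring would move the number beyond the scatter remains open. So does the effect of a longer chain in place of the aryl group.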